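Two Fluorines Instead of One: Estimating Compound 3

A few compounds are considered here, and "the series" means these few. Any claim that something is new, unique, unknown or untested is made for them only; others in the source may bear on it.

Compound 1: `Cc1nn(C)c(Oc2ccccc2F)c1/C=N\CCCCCCOc1cc2oc(=O)cc(C)c2cc1Cl`. In a functional assay on U-87MG ATCC cells for antiproliferative activity against U-87 MG (Homo sapiens), read by MTT assay, with a stated time of 72 h (on this read-out higher numbers stand for weaker inhibition and lower numbers for stronger inhibition), compound 1 gives > 25000 nM, which is a limit of the assay rather than a number.
Compound 2: `Cc1nn(C)c(Oc2ccc(F)cc2)c1/C=N\CCCCCCOc1cc2oc(=O)cc(C)c2cc1Cl`. In this assay compound 2 gives 16700 nM.

Among the measured compounds shown here, compound 2 holds the only actual number in this assay, since the other value shown is a limit, (the limit of > 25000 nM in this assay, at which 1 of the 2 values shown sits). Compound 3, `Cc1nn(C)c(Oc2ccc(F)cc2F)c1/C=N\CCCCCCOc1cc2oc(=O)cc(C)c2cc1Cl`, is not yet measured. It differs from compound 2 by fluoro in place of hydrogen on an aromatic carbon. For the measured compounds named here, the one measured step that bears on this change is an at least 1.4-fold lower number from compound 1 to compound 2 (0.17 log units; that floor lies within the scatter), which moved a fluoro from one position to another and did not clear the scatter. Going by the values given here, compound 3 keeps the fluoro of compound 2 and adds back the one that compound 1 carried, so no step beyond the scatter is expected in this assay. Compound 3 is therefore expected to give about 20000 nM, within 9000 nM to 45000 nM. That estimate means an expected step of a 1.2-fold higher number from compound 2 to compound 3 (0.08 log units; within the scatter).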

Compound 3, half-maximal inhibitory concentration: > 25000 nM
Compound 3 gave a limit, no number; the forecaster's own chance of this, stated with the estimate: 35%; middle value at least 1.2-fold (0.09 log units) from the limit.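

Adding a fluoro on an aromatic carbon, ortho to a large group, turns 4-fluorophenyl into 2,4-difluorophenyl and gives an at least 1.4-fold higher number from compound 2 to compound 3 (0.17 log units; that floor lies within the scatter) in this assay. The true size of this step may be larger than that floor, but the floor alone shows no change beyond the scatter. Both compounds with a fluoro at this place now sit at a limit, and only compound 2, with hydrogen there, gives a number, so the step between compound 1 and compound 3 cannot be read, and most of the series rests on one boundary: the limit of > 25000 nM in this assay, at which 2 of the 3 values shown sit.

As far as these compounds go, whether this place tolerates any group other than hydrogen stays open. A chloro or a methoxy group there could show whether the result belongs to fluoro alone or to any group at this place.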